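The source may report more compounds than this note shows. Statements on the series, on what has been measured and on what is new or still open speak of the compounds shown alone.

In a functional assay on HT-29 cells (Homo sapiens) for inhibition, read by MTT assay (a lower number here means a stronger inhibitor, a higher number a weaker inhibitor), compound 1 `COc1ccc(/C=C2\c3cc(OC)c(OC)c(OC)c3CC[C@@H]2O)cc1N` gives 160 nM and compound 2 `COc1ccc(/C=C2\c3cc(OC)c(OC)c(OC)c3CC[C@@H]2O)cc1O` gives 260 nM. Compound 3 `COc1ccc(/C=C2\c3cc(OC)c(OC)c(OC)c3CC[C@H]2O)cc1N` gives 910 nM, the highest number of the three. Compound 4 `COc1ccc(/C=C2\c3cc(OC)c(OC)c(OC)c3CC[C@H]2O)cc1[N+](=O)[O-]` keeps the configuration of compound 3 but has nitro in place of amino on an aromatic carbon. The closest measured change at this place, hydroxy in place of amino, gave a 1.6-fold higher number from compound 1 to compound 2 (0.21 log units; within the scatter), within the scatter. The larger 5.7-fold higher number from compound 1 to compound 3 (0.75 log units; beyond the scatter) goes with the fact that compounds 1 and 3 differ only in the configuration as drawn, so it says nothing about nitro. Resting on the small step between compound 1 and compound 2, no change beyond the scatter is expected in this assay, with an estimated 1.4-fold higher number from compound 3 to compound 4 (0.15 log units; within the scatter). For compound 4 the estimate is 1300 nM, with an expected range from 400 nM to 4000 nM.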

Compound 4, half-maximal inhibitory concentration: > 10000 nM
Compound 4: a limit, no number (the forecaster's own chance of this, stated with the estimate: 5%); middle value at least 7.6-fold (0.88 log units) from the limit.
By their numbers in this assay, from the lowest: compounds 1 and 2 (each within the scatter of the next); then compound 3. At a limit, above all of these: compound 4.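

Nitro in place of amino, ortho to a methoxy group, gives an at least 10-fold higher number from compound 3 to compound 4 (1.04 log units; beyond the scatter) and so shows that this position does not accept every replacement of amino, whereas hydroxy gave a 1.6-fold higher number from compound 1 to compound 2 (0.21 log units; within the scatter) in the other configuration. From the compounds shown here alone, compound 4 reads > 10000 nM as a limit of the assay and not a number, so the true size of this step stays unknown.

Going by these compounds, whether nitro costs as much in the configuration of compound 1 stays open. So does how a carboxylic acid or a methylamino group would behave at this position.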